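The source may report more compounds than this note shows. Statements on the series, on what has been measured and on what is new or still open speak of the compounds shown alone.

Measured in a functional assay on ECa-109 cells for inhibition, with ECa-109 cell line (Homo sapiens) as the target, read by sulforhodamine B assay; a higher number here means a weaker inhibitor, a lower number a stronger inhibitor:

- Compound 1 `O=C1C=C(NC2CCCCC2)C(=O)c2c1nc1n2[C@H]2OC[C@@H](O)[C@H]2OC1`: > 16000 nM, a limit and not a number
- Compound 2 `O=C1C=C(NC2CCCC2)C(=O)c2c1nc1n2[C@H]2OC[C@@H](O)[C@H]2OC1`: > 16000 nM, a limit and not a number
- Compound 3 `CCOc1ccc(NC2=CC(=O)c3nc4n(c3C2=O)[C@H]2OC[C@@H](O)[C@H]2OC4)cc1`: 3210 nM

Compound 3, at 3210 nM, is the only one of the three that gave a true number. The other two stand at a limit: the limit of > 16000 nM in this assay, at which 2 of the 3 values shown sit.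

The next compound is compound 4 `Cc1ccc(NC2=CC(=O)c3nc4n(c3C2=O)[C@H]2OC[C@@H](O)[C@H]2OC4)cc1C`, which shares the core of compound 3. In it, 3,4-dimethylphenyl takes the place of 4-ethoxyphenyl on an amine nitrogen: 3,4-dimethylphenyl in place of 4-ethoxyphenyl on an amine nitrogen.

Among the compounds with values here, two measured steps bear on this change. Putting 4-ethoxyphenyl in place of cyclohexyl gave an at least 4.9-fold lower number from compound 1 to compound 3 (0.69 log units; beyond the scatter), and putting it in place of cyclopentyl gave an at least 4.9-fold lower number from compound 2 to compound 3 (0.69 log units; beyond the scatter). Both steps are open-ended, and neither swaps one aromatic group for another, so their size cannot simply be carried over. Compound 4 keeps the six-membered aromatic ring of compound 3, which makes compound 3 and its 3210 nM the natural anchor for an expectation.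

In this assay, no step beyond the scatter is expected, and no direction is favoured. The estimated change is a 1.1-fold lower number from compound 3 to compound 4 (0.03 log units; within the scatter). For compound 4 the expected value is 3000 nM, with an estimated range from 1000 nM to 10000 nM.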

Compound 4, half-maximal inhibitory concentration: 2820 nM
Estimate against measurement, compound 4: 1.1-fold (0.03 log units) above; low and high end bracket the measured number.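

In this assay, this is the only exchange of one aromatic group for another shown on this amine nitrogen, and it gives a 1.1-fold lower number from compound 3 to compound 4 (0.06 log units; within the scatter), so 3,4-dimethylphenyl and 4-ethoxyphenyl cannot be told apart here, even though the oxygen of 4-ethoxyphenyl is missing from 3,4-dimethylphenyl. Against cyclopentyl and cyclohexyl, 3,4-dimethylphenyl gives an at least 5.6-fold lower number from compound 2 to compound 4 (0.75 log units; beyond the scatter) and an at least 5.6-fold lower number from compound 1 to compound 4 (0.75 log units; beyond the scatter), so among these four compounds both aromatic groups give true numbers, while both saturated rings do not. Both of these steps are open-ended, and their real size stays hidden behind a value that is only a limit: the limit of > 16000 nM in this assay, at which 2 of the 4 values shown sit.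

The compounds shown leave open whether an unsubstituted phenyl, a pyridine ring or a benzyl group on this nitrogen would behave like these two aromatic groups. They also leave open whether either methyl group of 3,4-dimethylphenyl matters, and whether a single methyl or a carboxylic acid on the ring would move the number beyond the scatter.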